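A few compounds are considered here, and "the series" means these few. Any claim that something is new, unique, unknown or untested is made for them only; others in the source may bear on it.

Of the compounds shown here, three have been measured in an ADME assay on BJ cells (Homo sapiens) for cytotoxicity, with a stated time of 72 h (on this read-out lower numbers stand for an effect already at smaller amounts and higher numbers for an effect only at larger amounts of compound), so far.

Compound 1 (`C=C[C@@](C)(/C=C/c1ccc(O)cc1)CC/C=C/C#N`) gives a limit (> 36600 nM).
Compound 2 (`C=C[C@@](C)(/C=C/c1ccc(O)c(/C=C/c2ccc(Cl)cc2)c1)CCC=C(C)C`) gives a limit (> 36600 nM).
Compound 3 (`CCOC(=O)/C=C/c1cc(/C=C/[C@](C)(/C=C/c2ccc(OC)cc2)CCC=C(C)C)ccc1O`) gives a limit (> 36600 nM).

None of these three results is a true number, and together they show one shared ceiling (the limit of > 36600 nM in this assay, at which 3 of the 3 values shown sit). Compound 3 therefore stands with the other two compounds, and its place among them cannot be ranked.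

The next compound to be tested is compound 4 (`COc1ccc(/C=C/[C@@](C)(/C=C/c2ccc(O)cc2)CCC=C(C)C)cc1`). It differs from compound 3 in one place (hydrogen in place of 2-(ethoxycarbonyl)ethenyl on an aromatic carbon): hydrogen in place of 2-(ethoxycarbonyl)ethenyl on an aromatic carbon, ortho to a hydroxy group. The rest of the structure stays the same.

Within the data shown here, no pair of measured compounds differs in just one place, so the size of this change in this assay has not been seen directly. Still, compounds 1, 2 and 3 differ in several groups and all reach the same ceiling. On that basis, no step beyond the usual scatter is expected in either direction. The estimated step runs (a number no higher from compound 3 to compound 4 (the limit leaves the size open)) and rests on compound 3 with its limit (> 36600 nM). Compound 4 is expected at 36600 nM with an estimated range from 18000 nM to 60000 nM in this assay, and most likely only a limit will be reported.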

Compound 4, half-maximal effective concentration: > 36600 nM
Compound 4 was reported as a limit (the forecaster's own chance of this, stated with the estimate: 80%); the middle value sits exactly at the limit.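

Among these compounds, compound 3 and compound 4 both give only a limit in this assay, so no step between them can be read, and all the compounds shown sit at one shared ceiling: the limit of > 36600 nM in this assay, at which 4 of the 4 values shown sit.

The compounds shown leave open how much any single change in structure matters here, since none of them yet gives a true number.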